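The compounds below may be only part of what the source reports. "The series", "measured", "known", "first", "only" and "open" are said of these compounds alone.

Measured compounds in a functional assay on UACC-257 cells (Homo sapiens) for cytotoxicity, read by sulforhodamine B assay, with a stated time of 48 h, tested at 1 uM; on this read-out higher numbers stand for a weaker effect at the one concentration tested and lower numbers for a stronger effect:
compound 1, `COc1cc(-c2cc(/C=C/C(=O)c3ccc(N)cc3)[nH]n2)cc(OC)c1OC`, 91%
compound 2, `COc1cc(-c2cc(/C=C/C(=O)c3ccc(Cl)c(Cl)c3)[nH]n2)cc(OC)c1OC`, 90%
compound 3, `COc1ccc(C(=O)/C=C/c2cc(-c3cc(OC)c(OC)c(OC)c3)n[nH]2)cc1OC`, 81%

All three share one core and differ only in the aryl group on the carbonyl carbon. The steps among them are small: a number 1 percentage points lower from compound 1 to compound 2 (within the scatter), a number 10 percentage points lower from compound 1 to compound 3 (within the scatter) and a number 9 percentage points lower from compound 2 to compound 3 (within the scatter). Within the data shown here, compound 3 therefore stands within the scatter of both compound 1 and compound 2, and no compound of the three can be set apart from the others on this read-out.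

Compound 4, `COc1ccc(C(=O)/C=C/c2cc(-c3cc(OC)c(OC)c(OC)c3)n[nH]2)cc1`, has not been measured. It differs from compound 3 in one place: hydrogen in place of methoxy on an aromatic carbon. Among the measured compounds shown here, no measured step bears on this exact change; the three measured steps each swap the whole aryl group on the carbonyl carbon rather than remove a single methoxy from it, and every one of them stayed within the scatter. What can be said is that the read-out has so far not responded to any replacement of the aryl group, so the smaller change from compound 3 to compound 4 is not expected to produce a step beyond the scatter in this assay; the expected step is a number 5 percentage points higher from compound 3 to compound 4 (within the scatter). On this basis compound 4 is estimated at 86%, with a range from 72% to 100%.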

Compound 4, a percentage reported as activity, at one concentration (the size of the read-out at that concentration, not a potency): 87%
Compound 4: middle estimate off by 1 percentage points, on the low side; the range from low to high includes it.
By their numbers in this assay, from the lowest: compounds 3, 4, 2 and 1 (each within the scatter of the next).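

In this assay, hydrogen in place of methoxy on the aromatic carbon ortho to a methoxy group and meta to a large group gives a step that stays within the scatter (a number 6 percentage points higher from compound 3 to compound 4 (within the scatter)), so the loss of this single methoxy, which turns 3,4-dimethoxyphenyl into 4-methoxyphenyl, does not register on this read-out. Among these compounds, this is the first change confined to one substituent, and the same holds for methoxy in place of amino on an aromatic carbon (a number 4 percentage points lower from compound 1 to compound 4 (within the scatter)). The 4-methoxyphenyl group also cannot be told apart from 3,4-dichlorophenyl on the carbonyl carbon (a number 3 percentage points lower from compound 2 to compound 4 (within the scatter)), so all four compounds remain unseparated at the one concentration tested.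

Open, from the compounds shown here alone, is whether any group at these aromatic carbons would move the number beyond the scatter, for example a carboxylic acid, a morpholine or a longer chain such as butoxy, and whether the four compounds would separate at another concentration. Nothing available here gives a measured reason for the flat response to these changes.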